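Fluorophenyl ether series: adding a second fluoro

The source may hold more compounds than are shown below. What is called first, only, known or untested is meant among the compounds shown, and "the series" means these compounds.

Of the compounds shown here, three on the shared core have been measured in a functional assay on cells for antagonist activity at Free fatty acid receptor 1 (Homo sapiens), read by TR-FRET and inositol phosphate accumulation, with a stated time of 2 h; a lower number here means a stronger inhibitor, a higher number a weaker inhibitor. Compound 1 `Cc1cc(COc2cccc(F)c2)nc(-c2ccccn2)n1` gives 794 nM in this assay. Compound 2 `Cc1cc(COc2ccc(F)cc2)nc(-c2ccccn2)n1` gives 631 nM in this assay. Compound 3 `Cc1cc(COc2cccc(F)c2F)nc(-c2ccccn2)n1` gives 398 nM in this assay.

The cores of compound 1 and compound 2 differ as 4-fluorophenyl in place of 3-fluorophenyl on an oxygen on a saturated carbon; this gives a 1.3-fold lower number from compound 1 to compound 2 (0.10 log units; within the scatter). From compound 1 to compound 3 the change is fluoro in place of hydrogen on an aromatic carbon, and it gives a 2.0-fold lower number from compound 1 to compound 3 (0.30 log units; within the scatter).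

Compound 4 `Cc1cc(COc2ccc(F)cc2F)nc(-c2ccccn2)n1` is not yet measured in this assay. It differs from compound 2 as fluoro in place of hydrogen on an aromatic carbon. Among the measured compounds shown here, this is the same kind of change as the one from compound 1 to compound 3, but not the same: in compound 3 the entering fluoro sits ortho to a fluoro group and ortho to a large group, whereas in compound 4 it sits ortho to a large group and meta to a fluoro group. The ring carbon receiving the fluoro thus has a different neighbourhood in the two pairs.

For the measured compounds named here, only one measured step shows this kind of change, so the expectation rests on it alone. The step from compound 2 to compound 4 is estimated at a 2.0-fold lower number from compound 2 to compound 4 (0.29 log units; within the scatter) in this assay, in line with a 2.0-fold lower number from compound 1 to compound 3 (0.30 log units; within the scatter), starting from compound 2 at 631 nM. Compound 4 is accordingly expected to give 320 nM in this assay, with a range of 150 nM to 700 nM.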

Compound 4, half-maximal inhibitory concentration: 398 nM
Compound 4: middle estimate off by 1.2-fold (0.09 log units), on the low side; the measured number falls inside the stated range.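

Adding the second fluoro gives a 1.6-fold lower number from compound 2 to compound 4 (0.20 log units; within the scatter) in this assay. Set beside the earlier case, the change carries from one core to the other with no difference in size that can be resolved: the same change on two cores in this assay, a 2.0-fold lower number (0.30 log units; within the scatter) from compound 1 to compound 3 and a 1.6-fold lower number (0.20 log units; within the scatter) from compound 2 to compound 4, 1.3-fold (0.10 log units) apart, within the scatter of two such steps. Each step on its own also lies within the scatter, so the two pairs agree only in showing no resolved effect of the entering fluoro; they do not establish that this change makes a stronger inhibitor, and two pairs, with the fluoro in a different neighbourhood in each, do not show that the size of the step would hold on a further core.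

All four compounds shown differ only in the fluoro groups on the phenyl ring of the ether, so it remains open what a chloro, a methoxy or a nitrile would do on that ring in place of fluoro. Also open, from the compounds shown here alone, is whether an amine or a longer chain in place of the ether link, or a carboxylic acid on the shared core, would move the number in this assay beyond the scatter.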